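Ester aryl variants on a nitrophenyl amide core

A few compounds are considered here, and "the series" means these few. Any claim that something is new, unique, unknown or untested is made for them only; others in the source may bear on it.

Measured compounds:
compound 1 `O=C(OC1(C(=O)Nc2ccc([N+](=O)[O-])cc2)CCCCC1)c1ccc(C(F)(F)F)cc1`: 26 nM
compound 2 `O=C(OC1(C(=O)Nc2ccc([N+](=O)[O-])cc2)CCCCC1)c1ccc(Cl)cc1`: 10.3 nM
compound 3 `O=C(OC1(C(=O)Nc2ccc([N+](=O)[O-])cc2)CCCCC1)c1ccc(Br)cc1`: 236 nM

In a functional assay on NFS-60 cells (Mus musculus) for inhibition, read by MTT assay, with a stated time of 72 h (a higher number here means a weaker inhibitor, a lower number a stronger inhibitor), compound 3 gives the highest number of the three. The step of a 9.1-fold higher number from compound 1 to compound 3 (0.96 log units; beyond the scatter) and the step of a 23-fold higher number from compound 2 to compound 3 (1.36 log units; beyond the scatter) both lie beyond the scatter, so compound 3 is the weakest inhibitor on the numbers shown.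

Compound 4 `O=C(OC1(C(=O)Nc2ccc([N+](=O)[O-])cc2)CCCCC1)C(O)c1ccccc1` differs from compound 3 by hydroxy(phenyl)methyl in place of 4-bromophenyl on a carbonyl carbon. Going by the values given here, none of the measured steps exchanges the aryl ring itself; a 2.5-fold lower number from compound 1 to compound 2 (0.40 log units; beyond the scatter), a 9.1-fold higher number from compound 1 to compound 3 (0.96 log units; beyond the scatter) and a 23-fold higher number from compound 2 to compound 3 (1.36 log units; beyond the scatter) only swap the single substituent on that ring, and together they show that the position is sensitive, with the numbers spanning a wide range across three small changes. Among the compounds with values here, no measured pair tells how the ester partner behaves once the halogenated ring is replaced by hydroxy(phenyl)methyl, so direction cannot be read from the data.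

For compound 4 the estimate in this assay is 100 nM (range 15 nM to 800 nM). This corresponds to an expected step of a 2.4-fold lower number from compound 3 to compound 4 (0.37 log units; beyond the scatter), with the wide range reflecting the lack of any bearing step.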

Compound 4, half-maximal inhibitory concentration: 7.8 nM
The estimate for compound 4 lay 13-fold (1.11 log units) above the measured number; measured number outside the range, below it.
By their numbers in this assay, from the lowest: compounds 4 and 2 (each within the scatter of the next); then compound 1; then compound 3.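

In this assay, the ester carbonyl carbon does not need a halogen-bearing or trifluoromethyl-bearing aryl ring attached directly: hydroxy(phenyl)methyl gives a 30-fold lower number from compound 3 to compound 4 (1.48 log units; beyond the scatter) and a 3.3-fold lower number from compound 1 to compound 4 (0.52 log units; beyond the scatter), while a 1.3-fold lower number from compound 2 to compound 4 (0.12 log units; within the scatter) leaves compound 4 and compound 2 together at the low end of the series. The substituent swaps on the ring had shown only that this position is sensitive; this exchange shows that a partner with a hydroxy group and no halogen can match the best halogenated ester, compound 2. No evidence at hand accounts for this result.

Still open, going by these compounds, is whether a plain benzyl group, or an amine in place of the hydroxy group, would keep the number near that of compound 4. On these data alone, it is equally open whether a chloro group on the phenyl ring of hydroxy(phenyl)methyl would shift the number as strongly as the halogen swaps did.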